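A few compounds are considered here, and "the series" means these few. Any claim that something is new, unique, unknown or untested is made for them only; others in the source may bear on it.

Working notes on the hydrazone series. Three analogues built on one shared core have been run in an ADME assay on J774 cells (Mus musculus) for cytotoxicity, read by MTT assay, with a stated time of 48 h, tested at 100 ug/mL; on this read-out lower numbers stand for a stronger effect and higher numbers for a weaker effect at the one concentration tested. Compound 1 `O=C(N/N=C/c1ccccc1F)c1cnccn1` gives 100%, compound 3 `O=C(N/N=C/c1cccc(Br)c1)c1cnccn1` gives 100%, and compound 2 `O=C(N/N=C/c1ccc(F)cc1)c1cnccn1` gives 69%. Compound 2 thus holds the lowest of the three numbers; compound 1 and compound 3 both lie higher by a gap beyond the usual scatter, and the two of them cannot be told apart from each other. Among the measured compounds shown here, no two of the measured compounds differ in a single place, so no directly comparable step is available.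

For the measured compounds named here, compound 4 `CCOc1ccc(/C=N/NC(=O)c2cnccn2)cc1` is the next entry. ethoxy in place of fluoro on an aromatic carbon The series holds no step of this kind, so the direction rests only on where the three measured numbers sit. In this assay a moderate upward step, a number 16 percentage points higher from compound 2 to compound 4 (beyond the scatter), is expected, since compound 2 at 69% sits below compound 1 and compound 3. Compound 4 is accordingly estimated at 85%, between 60% and 100%.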

Compound 4, a percentage reported as activity, at one concentration (the size of the read-out at that concentration, not a potency): 98%
Compound 4: the middle estimate sits 13 percentage points below what was measured; the range from low to high includes it.
By their numbers in this assay, from the lowest: compound 2; then compounds 4, 1 and 3 (each within the scatter of the next).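

In this assay, ethoxy in place of fluoro on an aromatic carbon, para to a large group, gives a number 29 percentage points higher from compound 2 to compound 4 (beyond the scatter), the first single-place change the series offers. It shows that the read-out at this position responds to the group it carries, so the low number of compound 2 is tied to fluoro at this place and not to the shared core alone. Nothing measured on these compounds accounts for the size or direction of this step.

Going by these compounds, whether the step follows the oxygen that enters or the longer group as a whole stays open, and a methoxy group or an amine at this same place would bear on that. One pair also leaves open whether fluoro is unusual here or whether other small groups, such as chloro, behave in the same way.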